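The compounds below may be only part of what the source reports. "The series", "measured", "known", "first", "only" and "open" are said of these compounds alone.

Working notes on the cytotoxicity series. In an ADME assay on HEK293 cells (Homo sapiens) for cytotoxicity, read by reporter gene assay and resazurin assay, with a stated time of 48 h (on this read-out higher numbers stand for lower toxicity in this test and lower numbers for higher toxicity in this test), compound 1 `COc1c(Br)cccc1C(=O)Nc1ccc(Sc2nc3ccccc3s2)c(Cl)c1` gives > 100000 nM, which is a limit of the assay and not a number. Compound 3 `COc1c(Br)cc(Br)cc1C(=O)Nc1cccc(Cl)c1` likewise reaches only a limit, > 100000 nM. Compound 2 `O=C(Nc1ccccc1)c1cccc(Br)c1O` gives 82000 nM in this assay. Compound 1 thus stands at the limit of > 100000 nM in this assay, at which 2 of the 3 values shown sit. The next compound, compound 4 `O=C(Nc1ccc(Sc2nc3ccccc3s2)c(Cl)c1)c1cc(Br)ccc1O`, keeps the core of compound 1 and alters the acid-side ring: a group of 8 heavy atoms (6 carbon, 1 oxygen, 1 bromine; one six-membered aromatic ring of carbon only) in place of a group of 9 heavy atoms (7 carbon, 1 oxygen, 1 bromine; one six-membered aromatic ring of carbon only), on a carbonyl carbon. For the measured compounds named here, no step between measured compounds is available here; given compound 2 at 82000 nM, no shift beyond the scatter is expected in this assay. Compound 4 is expected at 90000 nM, with a range from 40000 nM to 100000 nM, so that the step of an at least 1.1-fold lower number from compound 1 to compound 4 (0.04 log units; that floor lies within the scatter) is expected to stay within the scatter.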

Compound 4, half-maximal cytotoxic concentration: 45000 nM
The estimate for compound 4 lay 2.0-fold (0.30 log units) above the measured number; low and high end bracket the measured number.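

In this assay, for the compounds shown here, placing 5-bromo-2-hydroxyphenyl on the carbonyl carbon gives the first readable step, an at least 2.2-fold lower number from compound 1 to compound 4 (0.34 log units; beyond the scatter), so a change at this place alone, on the core of compound 1, moves the read-out beyond the scatter. Compound 1 stands at a limit of the assay, so this step gives only a floor for the size of the change: the limit of > 100000 nM in this assay, at which 2 of the 4 values shown sit.

The compounds shown do not separate the contribution of the hydroxy group from that of the bromine's placement. From the compounds shown here alone, how an amine or a carboxylic acid in place of that hydroxy group would read also stays open.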